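Extending the Hydroxyalkyl Chain at the Cytotoxicity Limit

The source may hold more compounds than are shown below. What is called first, only, known or untested is meant among the compounds shown, and "the series" means these compounds.

The measured compounds:
Compound 1, `CS(=O)(=O)c1nn(Cc2nc3cc(Cl)ccc3n2CCCO)c2cnccc12`: in an ADME assay on HEp-2 cells (Homo sapiens) for cytotoxicity, with a stated time of 4 days (on this read-out lower numbers stand for higher toxicity in this test and higher numbers for lower toxicity in this test), compound 1 gives > 100000 nM, which is a limit of the test and not a number.
Compound 2, `CC(C)(O)CCn1c(Cn2nc(S(C)(=O)=O)c3ccncc32)nc2cc(Cl)ccc21`: compound 2 gives > 100000 nM in this assay, again a limit of the test.

Compound 2 therefore stands at the upper edge of what this assay reports, and it shares that position with compound 1 (the limit of > 100000 nM in this assay, at which 2 of the 2 values shown sit). Among the measured compounds shown here, the one measured step, a step that the two limits leave unreadable from compound 1 to compound 2, is unreadable in size, since both of its ends are limits.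

Compound 3, `CC(C)(O)CCCn1c(Cn2nc(S(C)(=O)=O)c3ccncc32)nc2cc(Cl)ccc21`, differs from compound 2 by 2-hydroxy-2-methylpropyl in place of 1-hydroxy-1-methylethyl on a saturated chain carbon, two bonds along the chain from an aromatic nitrogen. Only the unreadable step bears on this change, so no direction can be drawn from it. The expectation is that compound 3 also remains at the limit in this assay, with an estimated step that the limit leaves unreadable from compound 2 to compound 3 from compound 2. The estimate for compound 3 is 150000 nM, in the range 60000 nM to 400000 nM.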

Compound 3, half-maximal cytotoxic concentration: > 100000 nM
Compound 3: only a limit was reported; the forecaster's own chance of this, stated with the estimate: 85%; the middle value lies beyond the limit too.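

Compound 1, compound 2 and compound 3 all sit at one limit in this assay, and the steps among them cannot be read in size: the limit of > 100000 nM in this assay, at which 3 of the 3 values shown sit.

The compounds shown leave open how far these three hydroxyalkyl chains differ beyond that limit.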